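Methylation of the Pyrazole Nitrogen in the Aminopyrazolopyridinone Series

The source may report more compounds than this note shows. Statements on the series, on what has been measured and on what is new or still open speak of the compounds shown alone.

Three compounds of the shared core have numbers in an assay on isolated protein for inhibition of serine/threonine-protein kinase Chk2 (Homo sapiens), read by mobility shift assay, tested at 30 uM; on this read-out higher numbers stand for more inhibition at the one concentration tested (going by the name of the read-out) and lower numbers for less inhibition. Compound 1 `Nc1n[nH]c2cc(-c3ccccn3)[nH]c(=O)c12` gives 47% in this assay and stands second of the three. Compound 2 `CN1CCN(c2ccc(-c3cc4[nH]nc(N)c4c(=O)[nH]3)cc2)CC1` gives 68% in this assay, which is beyond the scatter above compound 1. Among the measured compounds shown here, compound 3 `Nc1n[nH]c2cc(CC3CCNCC3)[nH]c(=O)c12` gives 7% in this assay, beyond the scatter below compound 1; no single-point step connects any of the three, so only their values are compared here.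

Compound 4 `Cn1nc(N)c2c(=O)[nH]c(-c3ccccn3)cc21` is not yet measured in this assay. It differs from compound 1 by methyl in place of hydrogen on an aromatic nitrogen, on the aromatic nitrogen of the five-membered ring, next to the ring nitrogen. For the measured compounds named here, no measured pair tests this change, so its size is unknown from the data; the shared core carries a free aromatic nitrogen-hydrogen in all three measured compounds. The expectation is a decrease of moderate size, beyond the scatter, from compound 1 to compound 4 in this assay, written as a number 27 percentage points lower from compound 1 to compound 4 (beyond the scatter). The estimated value for compound 4 in this assay is 20%, with a range from 5% to 45%.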

Compound 4, a percentage reported as inhibition, at one concentration (the size of the read-out at that concentration, not a potency): 25%
Beside the measured number, compound 4's estimate is 5 percentage points below it; measured number inside the range.
By their numbers in this assay, from the lowest: compound 3; then compound 4; then compound 1; then compound 2.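

Methyl in place of hydrogen on the aromatic nitrogen of the five-membered ring gives the first single-place step in the series, and in this assay it is a number 22 percentage points lower from compound 1 to compound 4 (beyond the scatter), so this position does respond to substitution, which the earlier compounds, all with the free nitrogen-hydrogen, could not show. The free hydrogen is also not required for all inhibition at the one concentration tested: compound 4 still gives 25% in this read-out. Nothing available here bears on why the number falls.

On these data alone, whether an ethyl group, a longer chain or a chain ending in an amine on this nitrogen moves the number further remains open. Also open, as far as these compounds go, is whether the same methyl step holds with the substituents of compound 2 or compound 3 on the shared core.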